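The source may report more compounds than this note shows. Statements on the series, on what has been measured and on what is new or still open speak of the compounds shown alone.

In a functional assay on HeLa cells (Homo sapiens) for inhibition (a higher number here means a weaker inhibitor, a lower number a stronger inhibitor), compound 1 `Cc1cn(/C=C/C=O)c(=O)[nH]c1=O` gives 25000 nM. Compound 2 `CC(=O)/C=C/n1cc(C)c(=O)[nH]c1=O` carries methyl in place of hydrogen on a carbonyl carbon relative to compound 1. In this assay compound 2 reaches only a limit, > 100000 nM. As far as these compounds go, the step is an at least 4.0-fold higher number from compound 1 to compound 2 (0.60 log units; beyond the scatter); its true size stays open since it rests on (the limit of > 100000 nM in this assay, at which 1 of the 3 values shown sits). Compound 3 `O=C/C=C/n1c(=O)ccn([C@H]2C[C@H](O)[C@@H](CO)O2)c1=O` gives 15000 nM in this assay; how its core differs from the core of compound 1 is not broken down here. Compound 4 `CC(=O)/C=C/n1c(=O)ccn([C@H]2C[C@H](O)[C@@H](CO)O2)c1=O` carries methyl in place of hydrogen on a carbonyl carbon relative to compound 3, the same change as made between compound 1 and compound 2, at a place described in the same words. The step of a 5.3-fold higher number from compound 3 to compound 4 (0.73 log units; beyond the scatter) is therefore expected to be at least as large as an at least 4.0-fold higher number from compound 1 to compound 2 (0.60 log units; beyond the scatter), which may carry compound 4 toward the limit of this assay. For compound 4 the estimate is 80000 nM, expected to fall between 30000 nM and 300000 nM.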

Compound 4, half-maximal inhibitory concentration: > 100000 nM
Compound 4 gave a limit, no number (the forecaster's own chance of this, stated with the estimate: 40%); middle value at least 1.2-fold (0.09 log units) from the limit.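

The change from formyl to acetyl weakens inhibition on both cores, and the new step is an at least 6.6-fold higher number from compound 3 to compound 4 (0.82 log units; beyond the scatter). Compound 4 gives > 100000 nM, which is a limit of the assay and not a number. The direction of the step therefore carries from the core of compound 1 to the core of compound 3, but its size cannot be compared between the two cores: the same change on two cores in this assay, an at least 4.0-fold higher number (0.60 log units; beyond the scatter) from compound 1 to compound 2 and an at least 6.6-fold higher number (0.82 log units; beyond the scatter) from compound 3 to compound 4; the limit leaves it open whether they differ

The compounds shown leave open how this assay would read a longer chain in place of the acetyl methyl, as in propanoyl. They also leave open the effect of replacing the formyl group with a carboxylic acid or an amide.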